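Chain extension and benzyl swap in the triazole amide series

The source may hold more compounds than are shown below. What is called first, only, known or untested is meant among the compounds shown, and "the series" means these compounds.

Measured so far in a functional assay on SH-SY5Y cells (Homo sapiens) for cytotoxicity, tested at 300 nM; a lower number here means a stronger effect, a higher number a weaker effect of the compound at the concentration tested:
- compound 1 `O=C(CCCCCCn1cc(-c2cccnc2)nn1)Nc1ccccc1-c1ccccc1`: 88.2%
- compound 2 `O=C(CCCCCCCCn1cc(-c2cccnc2)nn1)Nc1ccccc1-c1ccccc1`: 35.6%

Compound 2 stands lowest of the two numbers in this assay; compound 1 sits higher by a gap beyond the scatter. Compound 3 `O=C(CCCCCCCCn1cc(-c2cccnc2)nn1)Nc1ccccc1Cc1ccccc1` is the next step from compound 2, the change being (benzyl in place of phenyl on an aromatic carbon). For the measured compounds named here, no step of this kind has been measured, so there is no precedent for its size; a small upward move in this assay, possibly none beyond the scatter, is expected, a number 9.4 percentage points higher from compound 2 to compound 3 (within the scatter). Compound 3 is therefore expected to give about 45%, within a range of 20% to 75%.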

Compound 3, a percentage reported as activity, at one concentration (the size of the read-out at that concentration, not a potency): 74.7%
Compound 3: the middle estimate sits 29.7 percentage points below what was measured; low and high end bracket the measured number.
By their numbers in this assay, from the lowest: compound 2; then compound 3; then compound 1.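

In this assay, the position ortho to a large group proves sensitive to a small change: benzyl in place of phenyl, 7 heavy atoms against 6 with the same aromatic ring, gives a number 39.1 percentage points higher from compound 2 to compound 3 (beyond the scatter). The read-out at this place therefore depends on more than the presence of an aromatic ring. Nothing available explains the size of this step. The compounds shown leave open whether a phenethyl or a cyclohexyl group here would follow benzyl or phenyl, and whether the same swap would give a similar step on the chain of compound 1.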